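The compounds below may be only part of what the source reports. "The series", "measured", "known", "first", "only" and "open" are said of these compounds alone.

Measured compounds:
- compound 1 `ClCc1ccc(Cn2cnc3c(Cl)ncnc32)cc1`: 3460 nM
- compound 2 `ClCc1cccc(Cn2cnc3ncnc(Cl)c32)c1`: 14500 nM
- compound 3 `ClCc1cccc(Cn2cnc3c(Cl)ncnc32)c1`: 3310 nM

In a functional assay on M14 cells (Homo sapiens) for cytotoxicity, read by sulforhodamine B assay, with a stated time of 48 h (a lower number here means a stronger inhibitor of growth, a higher number a weaker inhibitor of growth), compound 1 gives 3460 nM, the second highest of the three numbers. Compound 3 sits at 3310 nM, a value within the usual scatter of compound 1, so the two cannot be told apart. Among the compounds with values here, compound 2 gives 14500 nM, a number beyond the scatter above both; it is the one with a chloro on the core placed differently, as its structure shows, but no single-change step connects it to compound 1, and only the two values themselves can be compared.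

Compound 4 `ClCc1ccc(Cn2cnc3c(Cl)nc(Cl)nc32)cc1` has not yet been measured. It differs from compound 1 by chloro in place of hydrogen on an aromatic carbon. No pair among the measured compounds isolates this change, so nothing shown gives the size of such a step. The expectation is a step from compound 1 to compound 4 of a 1.4-fold lower number from compound 1 to compound 4 (0.14 log units; within the scatter) in this assay, modest and possibly within the scatter. Compound 4 is estimated at 2500 nM, with a range of 700 nM to 9000 nM.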

Compound 4, concentration for total growth inhibition: 24000 nM
The estimate for compound 4 lay 9.6-fold (0.98 log units) below the measured number, and the stated range ends below it.
By their numbers in this assay, from the lowest: compounds 3 and 1 (each within the scatter of the next); then compounds 2 and 4 (each within the scatter of the next).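

In this assay, within the data shown here, chloro in place of hydrogen on the aromatic carbon between two ring nitrogen atoms gives a 6.9-fold higher number from compound 1 to compound 4 (0.84 log units; beyond the scatter), the only single-change step so far. This position is therefore sensitive to substitution: adding one chlorine atom moves the number beyond the scatter, towards a weaker inhibitor of growth. No measurement at hand accounts for this step.

An amine, a methoxy group or a methyl group at this carbon would show whether the step is specific to chloro or follows from any replacement of hydrogen there. Also open, from the compounds shown here alone, is whether the same change would give a step of similar size on compound 3, which differs from compound 1 in where its chloromethyl group sits.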